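A few compounds are considered here, and "the series" means these few. Any claim that something is new, unique, unknown or untested is made for them only; others in the source may bear on it.

Compound 1: `O=C(/C=C/c1ccc2c(c1)B(O)OC2)c1ccco1`. In a functional assay on MDA-MB-231 cells (Homo sapiens) for cytotoxicity, read by MTT assay, with a stated time of 48 h (a higher number here means a weaker inhibitor, a lower number a stronger inhibitor), compound 1 gives 7300 nM.
Compound 2: `Cn1cccc1C(=O)/C=C/c1ccc2c(c1)B(O)OC2`. For compound 2 the result is a limit of the assay, > 100000 nM.
Compound 3: `O=C(/C=C/c1ccc2c(c1)B(O)OC2)c1ccc(F)cc1`. Compound 3 gives 1600 nM.

Among the two numbers measured, compound 3 stands lowest; the step of a 4.6-fold lower number from compound 1 to compound 3 (0.66 log units; beyond the scatter) separates it from compound 1. The value of compound 2 is only a limit (the limit of > 100000 nM in this assay, at which 1 of the 3 values shown sits), so the steps of an at least 13-fold higher number from compound 1 to compound 2 (1.13 log units; beyond the scatter) and an at least 62-fold lower number from compound 2 to compound 3 (1.79 log units; beyond the scatter) are known only as minimum sizes.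

Compound 4 is `O=C(/C=C/c1ccc2c(c1)B(O)OC2)c1ccc(Cl)cc1`. It differs from compound 3 by a single change: chloro in place of fluoro on an aromatic carbon.

Going by the values given here, none of the measured steps touches this kind of change. Each of them swaps the entire ring on the carbonyl carbon, and their sizes, a 4.6-fold lower number from compound 1 to compound 3 (0.66 log units; beyond the scatter) and the two steps involving compound 2, tell nothing about exchanging one small substituent for another on a ring that otherwise stays the same. With no measured guide, the expectation for compound 4 is a step that stays within the usual scatter, neither clearly up nor clearly down.

Compound 4 is therefore estimated at 1300 nM, with a range from 400 nM to 4500 nM, meaning an expected step of a 1.2-fold lower number from compound 3 to compound 4 (0.09 log units; within the scatter).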

Compound 4, half-maximal inhibitory concentration: 7900 nM
Compound 4: the middle estimate sits 6.1-fold (0.78 log units) below what was measured; measured number above the stated range.
By their numbers in this assay, from the lowest: compound 3; then compounds 1 and 4 (each within the scatter of the next). At a limit, above all of these: compound 2.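

In this assay, replacing fluoro with chloro on the six-membered aromatic ring, para to a large group, gives a step beyond the scatter, a 4.9-fold higher number from compound 3 to compound 4 (0.69 log units; beyond the scatter), so a change of one atom at this place matters and not only a swap of the whole ring on the carbonyl carbon. With the 4-chlorophenyl ring in place of furan-2-yl the two numbers cannot be told apart, a 1.1-fold higher number from compound 1 to compound 4 (0.03 log units; within the scatter), so a six-membered aromatic ring on the carbonyl carbon does not by itself bring the lower number of compound 3. Compound 2 gives only a limit of the assay, > 100000 nM, so the step to the 4-chlorophenyl ring, an at least 12-fold lower number from compound 2 to compound 4 (1.10 log units; beyond the scatter), is known only as a minimum size.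

The data shown give no explanation for the difference between fluoro and chloro at this place. Also open, going by these compounds, is how a methoxy group, a nitrile or an amine at the same place would compare, and whether fluoro and chloro would differ in the same way on another ring.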